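A few compounds are considered here, and "the series" means these few. Any claim that something is new, unique, unknown or untested is made for them only; others in the source may bear on it.

Of the compounds shown here, two built on a shared core have been measured so far. Compound 1 `Cc1cccc(NC(=O)COc2ccc(/C=C3\SC(=O)NC3=O)cc2)n1` gives 58300 nM in a functional assay on PC-3 cells (Homo sapiens) for inhibition (a lower number here means a stronger inhibitor of growth, a higher number a weaker inhibitor of growth), and compound 2 `O=C(COc1ccc(/C=C2\SC(=O)NC2=O)cc1)Nc1ccc(Cl)cc1` gives 83400 nM in this assay. Among the compounds with values here, the only measured step, a 1.4-fold higher number from compound 1 to compound 2 (0.16 log units; within the scatter), swaps one aromatic ring for another on the amide-type nitrogen, and its size is within the scatter, so compound 2 and compound 1 stand together rather than apart.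

Compound 3 `O=C(COc1ccc(/C=C2\SC(=O)NC2=O)cc1)Nc1c(F)cc(Br)cc1F` is the next step from compound 2: 4-bromo-2,6-difluorophenyl in place of 4-chlorophenyl on an amide-type nitrogen. This is again an exchange of one aromatic ring for another at the same amide-type nitrogen. Within the data shown here, the one step that bears on it, a 1.4-fold higher number from compound 1 to compound 2 (0.16 log units; within the scatter), stayed within the scatter, so no step beyond the scatter is expected in this assay for compound 3 in either direction.

Compound 3 is therefore estimated at 80000 nM in this assay, with a likely range from 30000 nM to 200000 nM, which means an expected step of a 1.0-fold lower number from compound 2 to compound 3 (0.02 log units; within the scatter).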

Compound 3, concentration for 50% growth inhibition: > 100000 nM
Compound 3 was reported as a limit (the forecaster's own chance of this, stated with the estimate: 25%); middle value at least 1.2-fold (0.09 log units) from the limit.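

Compound 3 gives > 100000 nM in this assay, which is a limit of the assay and not a number: the limit of > 100000 nM in this assay, at which 1 of the 3 values shown sits.

The steps to it can therefore be read only as floors: an at least 1.1-fold higher number from compound 2 to compound 3 (0.07 log units; that floor lies within the scatter), and an at least 1.7-fold higher number from compound 1 to compound 3 (0.23 log units; that floor lies within the scatter). Neither floor reaches beyond the scatter, so the three aromatic rings on the amide-type nitrogen are not shown to differ from one another, although the limit hides how far compound 3 really lies from the other two.

As far as these compounds go, what stays open is whether anything other than an aromatic ring on this nitrogen would change growth inhibition, such as a cyclohexyl ring or a longer chain ending in an amine. The compounds shown also leave open how a carboxylic acid in place of the amide would behave.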